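The source may report more compounds than this note shows. Statements on the series, on what has been measured and on what is new or still open speak of the compounds shown alone.

Measured in a functional assay on A2780 cells (Homo sapiens) for inhibition, with a stated time of 72 h; on this read-out higher numbers stand for weaker inhibition and lower numbers for stronger inhibition:
compound 1 `CC1(C)CCOc2ccc(NC(=S)Nc3ccc(OC(F)(F)F)cc3)cc21` gives 4300 nM
compound 2 `CC1(C)CCOc2ccc(NC(=O)Nc3ccc(OC(F)(F)F)cc3)cc21` gives 3500 nM
compound 3 `CC1(C)CCOc2ccc(NC(=S)Nc3ccc(C(F)(F)F)cc3)cc21` gives 5500 nM

Compounds 1 and 3 share one core; the difference between the core of compound 1 and the core of compound 2 is not broken down here. From compound 1 to compound 3 the change is trifluoromethyl in place of trifluoromethoxy on an aromatic carbon, and in this assay it made a step of a 1.3-fold higher number from compound 1 to compound 3 (0.11 log units; within the scatter). Compound 2 has the lowest of the three numbers in this assay, but its gaps to compound 1 and to compound 3 both fall within the scatter, so no order among the three is claimed.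

Compound 4 `CC1(C)CCOc2ccc(NC(=O)Nc3ccc(C(F)(F)F)cc3)cc21` has not yet been measured in this assay. It differs from compound 2 by trifluoromethyl in place of trifluoromethoxy on an aromatic carbon, the same change as from compound 1 to compound 3, at a place described in the same words. The earlier step was within the scatter, and the same is expected here. Resting on compound 2 at 3500 nM and on that earlier step, the step expected for compound 4 is a 1.3-fold higher number from compound 2 to compound 4 (0.11 log units; within the scatter). Compound 4 is therefore expected to give about 4500 nM in this assay, most likely between 2500 nM and 8500 nM.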

Compound 4, half-maximal inhibitory concentration: 5000 nM
Compound 4: middle estimate off by 1.1-fold (0.05 log units), on the low side; low and high end bracket the measured number.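

In this assay, putting trifluoromethyl in place of trifluoromethoxy on an aromatic carbon made a 1.4-fold higher number from compound 2 to compound 4 (0.15 log units; within the scatter). The change therefore carried from one core to the other with no difference that can be told apart, as the two steps show: the same change on two cores in this assay, a 1.3-fold higher number (0.11 log units; within the scatter) from compound 1 to compound 3 and a 1.4-fold higher number (0.15 log units; within the scatter) from compound 2 to compound 4, 1.1-fold (0.05 log units) apart, within the scatter of two such steps

This rests on a single pair of compounds for each core, and neither step stands clear of the scatter, so it does not show that trifluoromethyl weakens inhibition on either core, nor that the change would behave alike on any further core.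

All four compounds carry either trifluoromethyl or trifluoromethoxy at this place on the aromatic ring, para to a large group, which leaves open how a nitrile, an amine or a carboxylic acid there would read in this assay. On these data alone, whether such a group would make matching steps on the two cores also remains open.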